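The source may hold more compounds than are shown below. What is called first, only, known or untested is meant among the compounds shown, and "the series" means these compounds.

Among three compounds measured in a functional assay on NUGC-3 cells (Homo sapiens) for cytotoxicity, read by sulforhodamine B assay, with a stated time of 72 h (on this read-out lower numbers stand for stronger inhibition of growth and higher numbers for weaker inhibition of growth), compound 1 `O=C(Nc1ccccc1C(F)(F)F)C1CCc2ccccc2N1C(=O)c1cccc(Cl)c1` gives the lowest number, 754 nM. Its nearest neighbour is compound 3 `O=C(Nc1cc(C(F)(F)F)cc(C(F)(F)F)c1)C1CCc2ccccc2N1C(=O)c1ccccc1Cl`, which in this assay gives 1930 nM, a gap beyond the scatter. Furthest away is compound 2 `O=C(Nc1ccccc1)C1CCc2ccccc2N1`, which in this assay gives 59000 nM. Compound 4 `CCCC(=O)N1c2ccccc2CCC1C(=O)Nc1ccccc1C(F)(F)F` is not yet measured. It differs from compound 1 in one place: propyl in place of 3-chlorophenyl on a carbonyl carbon. Within the data shown here, no measured pair tells what this change does. Since compound 2 gives 59000 nM while compound 1 gives 754 nM, the acyl group on the shared core seems to carry much of the activity, so the step from compound 1 to compound 4 is expected to weaken growth inhibition by a 4.0-fold higher number from compound 1 to compound 4 (0.60 log units; beyond the scatter). Compound 4 is therefore estimated at 3000 nM, in the range 800 nM to 12000 nM.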

Compound 4, concentration for 50% growth inhibition: > 70000 nM
Compound 4: a limit, no number; the forecaster's own chance of this, stated with the estimate: 5%; at least 23-fold (1.36 log units) between middle value and limit.
By their numbers in this assay, from the lowest: compound 1; then compound 3; then compound 2. At a limit, above all of these: compound 4.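

In this assay compound 4 gives > 70000 nM, a limit of the assay and not a number. Propyl in place of 3-chlorophenyl on a carbonyl carbon gives an at least 92-fold higher number from compound 1 to compound 4 (1.96 log units; beyond the scatter), so growth inhibition depends strongly on the group at this position, and propyl does not stand in for 3-chlorophenyl. Compound 4 is the only compound shown at such a limit: the limit of > 70000 nM in this assay, at which 1 of the 4 values shown sits.

The compounds shown leave open whether a longer chain such as hexyl, or a benzyl group, would keep growth inhibition at this position. They also leave open what the chlorine adds, as no unsubstituted phenyl group appears here on the same core.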